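The source may report more compounds than this note shows. Statements on the series, on what has been measured and on what is new or still open speak of the compounds shown alone.

Measured compounds in the series:
- compound 1 `COc1cc(C2=NN(C(C)=O)C(c3ccccc3C(F)(F)F)O2)cc(OC)c1OC`: 31.8%
- compound 2 `COc1cc(C(=O)N/N=C/c2cccc(C(F)(F)F)c2)cc(OC)c1OC`: 17.7%
- compound 3 `COc1cc(C(=O)N/N=C/c2ccc(Cl)c(Cl)c2)cc(OC)c1OC`: 29.6%

In a functional assay on BGC-823 cells (Homo sapiens) for antiproliferative activity, read by MTT assay, tested at 1 uM (on this read-out lower numbers stand for a weaker effect and higher numbers for a stronger effect at the one concentration tested), compound 1 gives 31.8%, the highest of the three numbers shown. Compound 3 gives 29.6%, which sits within the scatter of compound 1, so no order between these two can be read. Compound 2 gives 17.7%, a gap to compound 1 that lies beyond the scatter. Among the compounds with values here, none of the measured compounds differ from one another in a single place, so no step between measured compounds is available on this read-out.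

Compound 4 `COc1cc(C2=NN(C(C)=O)C(c3cccc(C(F)(F)F)c3)O2)cc(OC)c1OC` has not yet been measured in this assay. It differs from compound 1 as follows: 3-(trifluoromethyl)phenyl in place of 2-(trifluoromethyl)phenyl on a saturated ring carbon. Within the data shown here, no measured pair shows the effect of this change on the shared core, so the step is not anchored by data. The step from compound 1 to compound 4 in this assay is expected to be a number 3.8 percentage points lower from compound 1 to compound 4 (within the scatter), that is, none beyond the scatter. Compound 4 is estimated at 28%, with a range from 15% to 42%.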

Compound 4, a percentage reported as inhibition, at one concentration (the size of the read-out at that concentration, not a potency): 27.9%
Beside the measured number, compound 4's estimate is 0.1 percentage points above it; low and high end bracket the measured number.
By their numbers in this assay, from the lowest: compound 2; then compounds 4, 3 and 1 (each within the scatter of the next).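

In this assay, within the data shown here, 3-(trifluoromethyl)phenyl in place of 2-(trifluoromethyl)phenyl on the saturated ring carbon gives a number 3.9 percentage points lower from compound 1 to compound 4 (within the scatter) and provides the first single-place step. At this one concentration, the read-out therefore separates neither of these two placements of the trifluoromethyl group on the phenyl ring, and no preference between them can be read. No measured information bears on this result.

On these data alone, it remains open whether a different substituent on this phenyl ring, such as a carboxylic acid or an amine in place of the trifluoromethyl group, would give a step beyond the scatter. Also open, as far as these compounds go, is what replacing the acetyl group on the shared core would do, and compound 2 and compound 3 offer no single-place link to settle either question.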